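Trimming a Nitrobenzyl Arm Down to Allyl

This account rests on a few compounds, and the source may have more. Where it says the series, first, only, none or still open, it means among the compounds named here.

Going by the values given here, in a functional assay on HT-1080 cells (Homo sapiens) for antiproliferative activity, read by MTT assay (a higher number here means a weaker inhibitor, a lower number a stronger inhibitor), compound 2 `Cc1cc(=O)c(O)c(C(c2ccc(OCc3ccc([N+](=O)[O-])cc3)cc2)c2oc(C)cc(=O)c2O)o1` gives 3060 nM and this is the only true number so far. In this assay compound 1 `Cc1cc(=O)c(O)c(Cc2ccc(Cl)cc2)o1` returns only a limit (> 50000 nM) rather than a number.

Compound 3 `C=CCOc1ccc(C(c2oc(C)cc(=O)c2O)c2oc(C)cc(=O)c2O)cc1` keeps the core of compound 2 and alters one place (vinyl in place of 4-nitrophenyl on a saturated chain carbon bound to an oxygen on an aromatic ring): vinyl in place of 4-nitrophenyl on a saturated chain carbon bound to an oxygen on an aromatic ring. The (4-nitrobenzyl)oxy group thus becomes allyloxy.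

Among the compounds with values here, no measured pair shows this kind of change, so the expectation is loose: a moderate step in this assay toward a weaker inhibitor, slightly beyond the usual scatter. The estimated step (a 2.0-fold higher number from compound 2 to compound 3 (0.29 log units; within the scatter)) carries wide margins. In this assay compound 3 is expected at 6000 nM with 1800 nM to 20000 nM as the estimated range.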

Compound 3, half-maximal inhibitory concentration: 28300 nM
Estimate against measurement, compound 3: 4.7-fold (0.67 log units) below; measured number outside the range, above it.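

In this assay, trimming the arm gives a 9.2-fold higher number from compound 2 to compound 3 (0.97 log units; beyond the scatter), so the group on this saturated chain carbon clearly counts for the read-out. The change removes a six-membered aromatic ring and a nitro group at once, yet compound 3 still gives a true number, 28300 nM, so activity is weakened here rather than lost. Compound 1 differs from these two in more than one place and offers no comparison for this step, as its value is only a limit: the limit of > 50000 nM in this assay, at which 1 of the 3 values shown sits.

The step cannot be split between the loss of the ring and the loss of the nitro group, and a plain benzyl group would separate the two. On these data alone, whether an amine on that ring, or a longer chain in place of allyl, would recover activity also remains open.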